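A larger group on a saturated chain carbon

The source may report more compounds than this note shows. Statements on the series, on what has been measured and on what is new or still open speak of the compounds shown alone.

In an assay on SW1353 cells (Homo sapiens) for inhibition, read by a luciferase reporter, with stated times of 30 min and 8 h (a lower number here means a stronger inhibitor, a higher number a weaker inhibitor), compound 1 `O=c1oc2ccccc2n1CCCCCN1CCN(CCn2c(=O)oc3ccccc32)CC1` gives 4780 nM, compound 2 `O=c1sc2ccccc2n1CCCCCN1CCN(CCn2c(=O)sc3ccccc32)CC1` gives 1710 nM and compound 3 `O=c1sc2ccccc2n1CCCCCCN1CCN(CCn2c(=O)sc3ccccc32)CC1` gives 2950 nM. Compound 3 has the middle number of the three, but it lies within the usual scatter of both other compounds, so that place means little.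

Compound 4 `O=c1sc2ccccc2n1CCCCCCN1CCN(CCCCn2c(=O)sc3ccccc32)CC1` differs from compound 3 in one place: a group of 12 heavy atoms (9 carbon, 1 nitrogen, 1 oxygen, 1 sulfur; one five-membered aromatic ring with 2 hetero atoms, one six-membered aromatic ring of carbon only) in place of a group of 10 heavy atoms (7 carbon, 1 nitrogen, 1 oxygen, 1 sulfur; one five-membered aromatic ring with 2 hetero atoms, one six-membered aromatic ring of carbon only), on a saturated chain carbon, two bonds along the chain from an amine nitrogen in a ring.

Going by the values given here, only one measured step bears on this change: a 1.7-fold higher number from compound 2 to compound 3 (0.24 log units; within the scatter). That step also puts a larger group on a saturated chain carbon, and it stays small. However, it lies five bonds along the chain from an amine nitrogen in a ring, whereas the new change lies two bonds along. A single step at another place is only a loose guide, so no shift beyond the scatter is expected in this assay.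

The expected step is a 1.1-fold higher number from compound 3 to compound 4 (0.05 log units; within the scatter). Compound 4 is estimated at 3300 nM, with an expected range of 1400 nM to 7500 nM.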

Compound 4, half-maximal inhibitory concentration: 830 nM
Beside the measured number, compound 4's estimate is 4.0-fold (0.60 log units) above it; measured number below the stated range.
By their numbers in this assay, from the lowest: compound 4; then compounds 2, 3 and 1 (each within the scatter of the next, the first and the last beyond it).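

In this assay, putting the group of 12 heavy atoms in place of the group of 10 heavy atoms, on a saturated chain carbon, two bonds along the chain from an amine nitrogen in a ring, gives a 3.6-fold lower number from compound 3 to compound 4 (0.55 log units; beyond the scatter). Among the steps shown, only this one lies beyond the scatter, so this place responds to a larger group in a way that the earlier step, a 1.7-fold higher number from compound 2 to compound 3 (0.24 log units; within the scatter), five bonds along the chain, did not show. Nothing measured here accounts for the drop.

The compounds shown leave open whether a still longer chain at this place would lower the number further or raise it again. They also leave open whether an amine on this chain would keep the lower number.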